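This account rests on a few compounds, and the source may have more. Where it says the series, first, only, none or still open, it means among the compounds named here.

Compound 1 `Cc1ccc(NC(=O)C2CCN(C/C=C/c3ccccc3)CC2)cc1` gives 33900 nM
Compound 2 `O=C(Nc1cccc(C(F)(F)F)c1)C1CCN(C/C=C/c2ccccc2)CC1` gives 11400 nM
Compound 3 `O=C(Nc1ccc(F)c(Br)c1)C1CCN(C/C=C/c2ccccc2)CC1` gives 8190 nM

In a functional assay on HepG2 cells (Homo sapiens) for inhibition, read by MTT assay, with a stated time of 72 h (on this read-out higher numbers stand for weaker inhibition and lower numbers for stronger inhibition), compound 1 has the highest number of the three, with compound 2 the nearest to it and compound 3 the furthest. Compound 4 `CN1CCN(c2ccc(NC(=O)C3CCN(C/C=C/c4ccccc4)CC3)cc2)CC1` has not yet been measured. It departs from compound 1 by one change, (4-methylpiperazin-1-yl in place of methyl on an aromatic carbon), which puts 4-methylpiperazin-1-yl in place of methyl on an aromatic carbon, para to a large group.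

Within the data shown here, only one measured step bears directly on this. It is a 4.1-fold lower number from compound 1 to compound 3 (0.62 log units; beyond the scatter), a modest step that also removes the methyl, along with the 4-methylphenyl that carries it. Compound 2, which lacks that methyl too, likewise sits below compound 1. Neither compound carries a 4-methylpiperazin-1-yl group, so the guidance is loose. A modest move towards a lower number is expected in this assay. The expected step is a 2.3-fold lower number from compound 1 to compound 4 (0.35 log units; beyond the scatter). Compound 4 is estimated at 15000 nM, within an expected range from 5000 nM to 45000 nM.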

Compound 4, half-maximal inhibitory concentration: 35200 nM
Beside the measured number, compound 4's estimate is 2.3-fold (0.37 log units) below it; low and high end bracket the measured number.
By their numbers in this assay, from the lowest: compounds 3 and 2 (each within the scatter of the next); then compounds 1 and 4 (each within the scatter of the next).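

In this assay, replacing methyl with 4-methylpiperazin-1-yl on the aromatic carbon, para to a large group, gives a 1.0-fold higher number from compound 1 to compound 4 (0.02 log units; within the scatter), so this position accepts a much larger group, carrying a six-membered non-aromatic ring, with no measurable change in the number. Removing the methyl therefore does not by itself go with a lower number, and the earlier 4.1-fold lower number from compound 1 to compound 3 (0.62 log units; beyond the scatter) belongs to the whole 3-bromo-4-fluorophenyl change, not simply to the loss of that methyl. Nothing measured here explains why the larger group leaves the number unchanged.

As far as these compounds go, it remains open whether a morpholine ring, a dimethylamino group or a carboxylic acid at this position would also match compound 1. From the compounds shown here alone, it is also open whether 4-methylpiperazin-1-yl would behave the same way on the bromo- and fluoro-substituted ring of compound 3.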